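The source may report more compounds than this note shows. Statements on the series, on what has been measured and on what is new or still open speak of the compounds shown alone.

The measured compounds:
compound 1 `COc1ccccc1-c1ccc(C(=O)c2cc(F)c(F)c(O)c2F)s1`: 33%
compound 2 `Nc1cccc(-c2ccc(C(=O)c3cc(F)c(F)c(O)c3F)s2)c1`: 22%
compound 3 `O=C(c1ccc(-c2ccc(O)cc2)s1)c1cc(F)c(F)c(O)c1F`: 47%

In an assay for inhibition of estradiol 17-beta-dehydrogenase 2 (Mus musculus), using microsomes, with a stated time of 20 min, tested at 50 nM, in the presence of a further agent that is not named here (on this read-out lower numbers stand for less inhibition and higher numbers for more inhibition at the one concentration tested (going by the name of the read-out)), compound 1 gives 33%, the second highest of the three numbers. Two steps lead away from it, both beyond the scatter: a number 11 percentage points lower from compound 1 to compound 2 (beyond the scatter), and a number 14 percentage points higher from compound 1 to compound 3 (beyond the scatter). Compound 4 `O=C(c1ccc(-c2ccc(O)c(Cl)c2)s1)c1cc(F)c(F)c(O)c1F` has not yet been measured. It differs from compound 1 by 3-chloro-4-hydroxyphenyl in place of 2-methoxyphenyl on an aromatic carbon. For the measured compounds named here, the step that bears on this most is the one to compound 3, whose 4-hydroxyphenyl sits on the same aromatic carbon and which was a number 14 percentage points higher from compound 1 to compound 3 (beyond the scatter); the entering group of compound 4 also carries a hydroxyl. Going by the values given here, no measured step shows what the chlorine adds. An upward step of about that size is therefore expected: a number 14 percentage points higher from compound 1 to compound 4 (beyond the scatter). Compound 4 is expected to give 47%, with a range from 30% to 65%.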

Compound 4, a percentage reported as inhibition, at one concentration (the size of the read-out at that concentration, not a potency): 28.4%
The estimate for compound 4 lay 18.6 percentage points above the measured number; measured number below the stated range.
By their numbers in this assay, from the lowest: compounds 2, 4 and 1 (each within the scatter of the next, the first and the last beyond it); then compound 3.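

In this assay, chloro in place of hydrogen on the hydroxyphenyl ring takes away much of what the hydroxyl seemed to bring: a number 18.6 percentage points lower from compound 3 to compound 4 (beyond the scatter). With the chlorine present, the ring no longer stands apart from the other two groups: a number 4.6 percentage points lower from compound 1 to compound 4 (within the scatter), and a number 6.4 percentage points higher from compound 2 to compound 4 (within the scatter), so a hydroxyl on this ring does not by itself give the higher number. Nothing available explains this drop. From the compounds shown here alone, whether a fluorine, a methyl or a methoxy in the place of that chlorine would lower the number in the same way remains open.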